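Isomeric dialkylamino swap on the quinoline nitrogen neighbour

The source may hold more compounds than are shown below. What is called first, only, known or untested is meant among the compounds shown, and "the series" means these compounds.

Compound 1 `CC(C)N(C)c1ccc2cc(NC(=O)CCc3ccc(C(F)(F)F)cc3)ccc2n1` carries an isopropyl(methyl)amino group on the shared core. For the measured compounds named here, in a functional assay on HEK293 cells for activation of melanin-concentrating hormone receptor 1 (Rattus norvegicus), read by inositol phosphate accumulation (a higher number here means that more compound is needed for the effect, a lower number that less compound is needed), compound 1 gives 140 nM, the lower of the two numbers measured so far. Going by the values given here, the only other measured member, compound 2 `O=C(CCc1ccc(C(F)(F)F)cc1)Nc1ccc2nc(N3CCC(c4ccccc4)C3)ccc2c1`, gives 1770 nM in this assay; the step of a 13-fold higher number from compound 1 to compound 2 (1.10 log units; beyond the scatter) arises from a 3-phenylpyrrolidin-1-yl in place of isopropyl(methyl)amino on an aromatic carbon.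

Compound 3 `CCN(CC)c1ccc2cc(NC(=O)CCc3ccc(C(F)(F)F)cc3)ccc2n1` differs from compound 1 by diethylamino in place of isopropyl(methyl)amino on an aromatic carbon. Among the compounds with values here, no measured step shows an exchange of two acyclic dialkylamino groups of equal size; the only step known, from compound 1 to compound 2, involves a ring-bearing group and is therefore of limited bearing here. Given that the atoms are merely rearranged, a step within the usual scatter is expected for compound 3 in this assay, expressed as a 1.3-fold higher number from compound 1 to compound 3 (0.11 log units; within the scatter), with a slight lean towards a higher number left open.

Compound 3 is accordingly estimated at 180 nM in this assay, with a range from 70 nM to 450 nM.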

Compound 3, half-maximal effective concentration: 830 nM
Estimate against measurement, compound 3: 4.6-fold (0.66 log units) below; measured number outside the range, above it.
By their numbers in this assay, from the lowest: compound 1; then compound 3; then compound 2.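

In this assay, the place on an aromatic carbon next to the ring nitrogen separates two acyclic amino groups with the same heavy-atom count, no ring and the same hydrogen-bond counts: diethylamino in place of isopropyl(methyl)amino gives a 5.9-fold higher number from compound 1 to compound 3 (0.77 log units; beyond the scatter), so the way the same atoms are joined is enough to move the number beyond the scatter. The step of a 2.1-fold lower number from compound 2 to compound 3 (0.33 log units; beyond the scatter) shows that diethylamino still holds a lower number than 3-phenylpyrrolidin-1-yl, but the order of compound 1, then compound 3, then compound 2 also shows that a higher number here does not depend on a ring-bearing group. Nothing available explains why the two isomeric groups differ.

Going by these compounds, whether isopropyl(methyl)amino is itself the favoured arrangement or only one of several remains open, and dimethylamino, isopropyl(ethyl)amino and diisopropylamino at this place would help to separate the contribution of each alkyl arm. Pyrrolidin-1-yl without its phenyl would show how much of the number for compound 2 belongs to the ring and how much to the phenyl on it.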